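Two Fluorine Substitutions on the Same Aromatic Ring

This account rests on a few compounds, and the source may have more. Where it says the series, first, only, none or still open, it means among the compounds named here.

Compound 1 `Fc1ccccc1CSc1nnc(-c2cnccn2)o1` is the reference point of this small set. In a functional assay on HepG2 cells (Homo sapiens) for antiproliferative activity, read by MTT assay, with a stated time of 48 h (a lower number here means a stronger inhibitor, a higher number a weaker inhibitor), compound 1 gives 12500 nM. Compound 2 `Fc1ccc(CSc2nnc(-c3cnccn3)o2)c(F)c1` differs from compound 1 by fluoro in place of hydrogen on an aromatic carbon, the new fluoro standing meta to a fluoro group and para to a large group. In this assay compound 2 gives 14400 nM, and the change gave a 1.2-fold higher number from compound 1 to compound 2 (0.06 log units; within the scatter). Compound 3 `Fc1ccccc1CSc1nnc(-c2cnccn2)s1` has a different core from compound 1; the difference between the two cores is not broken down here. In this assay compound 3 gives 9520 nM, a value that lies within the scatter of those of compound 1 and of compound 2.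

Compound 4 `Fc1cccc(F)c1CSc1nnc(-c2cnccn2)s1` has not yet been measured. It differs from compound 3 by fluoro in place of hydrogen on an aromatic carbon, the same kind of change as that between compound 1 and compound 2, though not the same change: in compound 4 the entering fluoro sits ortho to a large group and meta to a fluoro group, whereas in compound 2 it sits meta to a fluoro group and para to a large group.

For compound 4 the expected step is a 1.1-fold higher number from compound 3 to compound 4 (0.04 log units; within the scatter), because the same kind of change gave a 1.2-fold higher number from compound 1 to compound 2 (0.06 log units; within the scatter) and that step lay within the scatter. Compound 4 is therefore estimated to give 10500 nM in this assay. The estimated range for compound 4 runs from 5000 nM to 22000 nM.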

Compound 4, half-maximal inhibitory concentration: 6900 nM
For compound 4 the middle estimate is 1.5-fold (0.18 log units) above the measured one, and the stated range covers the measured number.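

Putting a second fluoro on the aromatic ring gives a 1.4-fold lower number from compound 3 to compound 4 (0.14 log units; within the scatter), and like the earlier step, this one is no larger than the ordinary variation between repeated measurements. Set side by side in this assay, the two steps give no sign that the core alters what this kind of change does: the same change on two cores in this assay, a 1.2-fold higher number (0.06 log units; within the scatter) from compound 1 to compound 2 and a 1.4-fold lower number (0.14 log units; within the scatter) from compound 3 to compound 4, 1.6-fold (0.20 log units) apart, within the scatter of two such steps. This does not show that the change carries over identically from one core to the other: the entering fluoro stands at a different place on the ring in the two pairs, and steps this small could hide a modest real difference, so all that can be said is that neither pair shows a clear effect.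

Every compound shown carries only hydrogen or fluoro on this ring, which leaves open whether a larger group there, such as a methoxy group, an amine or a carboxylic acid, would move the number beyond the scatter. Also open, going by these compounds, is whether a longer chain between this ring and the core would change the picture, and whether the same fluoro change would stay as small on any further core.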